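Alkynyl for furanyl on a uracil antiproliferative scaffold

This account rests on a few compounds, and the source may have more. Where it says the series, first, only, none or still open, it means among the compounds named here.

Measured so far:
compound 1, `O=c1[nH]c(=O)n(CCC(CO)CO)cc1-c1ccco1`, > 100000 nM
compound 2, `CC(=O)OCC(CCn1cc(C#Cc2cc(F)cc(F)c2)c(=O)n(C(=O)c2ccccc2)c1=O)COC(C)=O`, > 100000 nM

In a functional assay on SW-620 cells (Homo sapiens) for antiproliferative activity, read by MTT assay, with a stated time of 72 h (on this read-out lower numbers stand for stronger inhibition and higher numbers for weaker inhibition), compound 1 gives only a limit, > 100000 nM, not a number. Compound 2 likewise returns a limit in this assay, > 100000 nM. Among the measured compounds shown here, compound 1 thus stands at the limit of > 100000 nM in this assay, at which 2 of the 2 values shown sit, which is all the measured values show; no step between measured compounds differing in one place exists here.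

Compound 3, `CCCCCC#Cc1cn(CCC(CO)CO)c(=O)[nH]c1=O`, has not been measured. It differs from compound 1 by hept-1-yn-1-yl in place of furan-2-yl on an aromatic carbon. With both measured compounds sitting at the limit, no direction for this change can be read from the numbers, and the step from compound 1 to compound 3 in this assay is expected to be none beyond the scatter, a number no higher from compound 1 to compound 3 (the limit leaves the size open). Compound 3 is therefore expected to give about 100000 nM, within 20000 nM to 300000 nM.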

Compound 3, half-maximal inhibitory concentration: > 100000 nM
Compound 3: only a limit was reported (the forecaster's own chance of this, stated with the estimate: 70%); the middle value sits exactly at the limit.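

Among the compounds shown here, compound 3, like compound 1, returns only a limit, so no step between compound 1 and compound 3 can be read: the limit of > 100000 nM in this assay, at which 3 of the 3 values shown sit. The compounds shown leave open whether any group on the shared core would give a measurable value in this assay at all.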